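The compounds below may be only part of what the source reports. "The series", "measured", "known", "first", "only" and "open" are said of these compounds alone.

Compound 1 `O=C(COc1ccc2ccccc2c1)N1CCN(C(c2ccc(Br)cc2)c2ccc(Br)cc2)CC1` gives 4.06% in a functional assay on PC-12 cells (Rattus norvegicus) for cytotoxicity, read by MTT assay, with a stated time of 24 h, tested at 0.1 uM; on this read-out lower numbers stand for a weaker effect and higher numbers for a stronger effect at the one concentration tested.
Compound 2 `Cc1ccc(C(c2ccc(C)cc2)N2CCN(C(=O)COc3ccc4ccccc4c3)CC2)cc1` gives 4.75% in this assay.
Compound 3 `COc1ccc(OCC(=O)N2CCN(C(c3ccc(C)cc3)c3ccc(C)cc3)CC2)cc1` gives 21.7% in this assay.

Compound 1 and compound 2 share the same acid part but differ in their cores; the difference between the two cores is not broken down here, and their two values lie within the scatter of each other. Compound 2 and compound 3 differ in one place: 4-methoxyphenyl in place of naphthalen-2-yl on an oxygen on a saturated carbon. The outcome of that single change is a number 17 percentage points higher from compound 2 to compound 3 (beyond the scatter).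

The unmeasured compound 4 `COc1ccc(OCC(=O)N2CCN(C(c3ccc(Br)cc3)c3ccc(Br)cc3)CC2)cc1` stands to compound 1 exactly as compound 3 stands to compound 2: 4-methoxyphenyl in place of naphthalen-2-yl on an oxygen on a saturated carbon. The place of the change is described in the same words in both pairs, so it is the same change made on a second core. Within the data shown here, the only guide to its effect is the one measured instance, a number 17 percentage points higher from compound 2 to compound 3 (beyond the scatter), and the expectation that follows rests on that alone. Compound 4 is therefore expected to show a step of a number 16.9 percentage points higher from compound 1 to compound 4 (beyond the scatter). Compound 4 is estimated at 21%, with a range from 8% to 35%.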

Compound 4, a percentage reported as activity, at one concentration (the size of the read-out at that concentration, not a potency): 3.52%
Compound 4: middle estimate off by 17.5 percentage points, on the high side, outside the stated range (below it).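

In this assay, putting 4-methoxyphenyl in place of naphthalen-2-yl on the core of compound 1 gave a step of a number 0.5 percentage points lower from compound 1 to compound 4 (within the scatter). Set beside the earlier instance, the change did not carry over from one core to the other with the same size: the same change on two cores in this assay, a number 17 percentage points higher (beyond the scatter) from compound 2 to compound 3 and a number 0.5 percentage points lower (within the scatter) from compound 1 to compound 4, 17.5 percentage points apart, beyond the scatter of two such steps. This shows that, for these two pairs, the step measured on one core was no guide to the step on the other, but it does not show which feature of the cores accounts for the gap, or which of the two steps would be the more typical on a further core.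

With only two cores and two aryl groups on the oxygen shown, it remains open how the change would behave on a third core. Going by these compounds, it also remains open whether an amine or a carboxylic acid in place of the methoxy group, or a longer chain in place of the single saturated carbon, would give a step that follows either pair.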